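Amide carbonyl substituent: tert-butyl to phenyl

A few compounds are considered here, and "the series" means these few. Any claim that something is new, unique, unknown or untested is made for them only; others in the source may bear on it.

Two amides on the shared core have been measured in a functional assay on B16-F10 cells (Mus musculus) for antiproliferative activity, read by MTT assay, with a stated time of 48 h; a higher number here means a weaker inhibitor, a lower number a stronger inhibitor. Compound 1 `COc1ccc(-c2cn3cc(C4=CCN(C(=O)c5ccc(Cl)cc5)CC4)ccc3n2)cc1OC` gives 15300 nM; compound 2 `COc1ccc(-c2cn3cc(C4=CCN(C(=O)C(C)(C)C)CC4)ccc3n2)cc1OC` gives 7100 nM, the lowest of the two numbers. For the measured compounds named here, the one step between them, a 2.2-fold lower number from compound 1 to compound 2 (0.33 log units; beyond the scatter), replaced 4-chlorophenyl by tert-butyl on the carbonyl carbon and lowered the number modestly, beyond the scatter. Compound 3 `COc1ccc(-c2cn3cc(C4=CCN(C(=O)c5ccccc5)CC4)ccc3n2)cc1OC` is not yet measured; it differs from compound 2 by phenyl in place of tert-butyl on a carbonyl carbon. Going by the values given here, the only step bearing on this change is a 2.2-fold lower number from compound 1 to compound 2 (0.33 log units; beyond the scatter), which runs from an aromatic carbonyl substituent to an alkyl one; the present change runs the other way, from tert-butyl back to an aromatic group, though without the chlorine of compound 1. A modest rise in the number is therefore expected, about the size of a 1.5-fold higher number from compound 2 to compound 3 (0.19 log units; within the scatter). Compound 3 is expected to give about 11000 nM, within a range of 5000 nM to 25000 nM.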

Compound 3, half-maximal inhibitory concentration: 8370 nM
Beside the measured number, compound 3's estimate is 1.3-fold (0.12 log units) above it; the range from low to high includes it.
By their numbers in this assay, from the lowest: compounds 2, 3 and 1 (each within the scatter of the next, the first and the last beyond it).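

In this assay, phenyl and tert-butyl on the carbonyl carbon are not told apart, with a 1.2-fold higher number from compound 2 to compound 3 (0.07 log units; within the scatter). The chloro group on the aromatic ring is not separated from hydrogen either, with a 1.8-fold lower number from compound 1 to compound 3 (0.26 log units; within the scatter). The gap beyond the scatter between compound 1 and compound 2 therefore cannot be assigned to the chloro group alone or to the change from an aromatic to an alkyl group, since compound 3 lies within the scatter of both. Open, as far as these compounds go, is whether a different carbonyl substituent, such as a longer alkyl chain, a primary amine or a carboxylic acid, or a methoxy group in place of the chloro group, would move the number beyond the scatter. No measurement available here offers an explanation for these numbers.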